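The source may hold more compounds than are shown below. What is called first, only, known or untested is meant among the compounds shown, and "the series" means these compounds.

In a functional assay on MCF7 cells (Homo sapiens) for cytotoxicity, read by MTT assay, with a stated time of 72 h (a lower number here means a stronger inhibitor, a higher number a weaker inhibitor), compound 1 `C=C1C2=C(C(=O)N1OC)[C@H](OC(=O)CCCCCl)[C@@](C)(O)[C@H](CCCCC)O2` gives 5400 nM and compound 2 `C=C1C2=C(C(=O)N1OC)[C@H](OC(=O)CSc1nc3ccccc3[nH]1)[C@@](C)(O)[C@H](CCCCC)O2` gives 16000 nM, the higher of the two numbers. Compound 3 `C=C1C2=C(C(=O)N1OC)[C@H](OC(=O)CCl)[C@@](C)(O)[C@H](CCCCC)O2` differs from compound 2 in one place: chloro in place of (1H-benzimidazol-2-yl)sulfanyl on a saturated chain carbon bound to a carbonyl carbon. Going by the values given here, the only measured step bearing on this change is the modest 3.0-fold higher number from compound 1 to compound 2 (0.47 log units; beyond the scatter), with (1H-benzimidazol-2-yl)sulfanyl in place of 3-chloropropyl. Removing that group is therefore expected to give a step of similar size towards a lower number in this assay, estimated as a 2.7-fold lower number from compound 2 to compound 3 (0.43 log units; beyond the scatter). The estimate for compound 3 is 6000 nM, with an expected range of 2000 nM to 15000 nM.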

Compound 3, half-maximal inhibitory concentration: 17000 nM
Beside the measured number, compound 3's estimate is 2.8-fold (0.45 log units) below it; the whole stated range lies below it.
By their numbers in this assay, from the lowest: compound 1; then compounds 2 and 3 (each within the scatter of the next).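

Chloro in place of (1H-benzimidazol-2-yl)sulfanyl on a saturated chain carbon bound to a carbonyl carbon gives a 1.1-fold higher number from compound 2 to compound 3 (0.03 log units; within the scatter) and so shows no change on losing the two-ring group. The separation at this position now rests with 3-chloropropyl, since chloro in its place gives a 3.1-fold higher number from compound 1 to compound 3 (0.50 log units; beyond the scatter) and leaves compound 1 apart from both other compounds. Nothing measured here accounts for either step. Open, from the compounds shown here alone, is whether the chlorine of 3-chloropropyl or the chain itself carries this separation. A plain butyl chain, an amine or a carboxylic acid at this position would test that.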